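Tert-Butyl for Ethyl on the Urea Aryl Ring

The source may report more compounds than this note shows. Statements on the series, on what has been measured and on what is new or still open speak of the compounds shown alone.

Going by the values given here, in an ADME assay on the whole organism with Oryza sativa as the target, tested at 10 uM (a lower number here means a stronger effect, a higher number a weaker effect of the compound at the concentration tested), compound 2 `CCc1ccccc1NC(=O)N[C@@H](C)c1ccccc1` gives 95%, the highest of the three numbers known so far. Compound 1 `CCc1ccccc1NC(=O)N[C@H](C)c1ccccc1` gives 92%, and the step of a number 3 percentage points higher from compound 1 to compound 2 (within the scatter) is in keeping with the fact that compounds 1 and 2 differ only in the configuration as drawn. Compound 3 `CCc1cccc(NC(=O)N[C@H](C)c2ccccc2)c1` gives 36%, a value far below that of compound 2. Compound 4 `C[C@H](NC(=O)Nc1ccccc1C(C)(C)C)c1ccccc1` differs from compound 2 by tert-butyl in place of ethyl on an aromatic carbon. Among the compounds with values here, the only measured step, the inversion of configuration from compound 1 to compound 2, was within the scatter and tells little about swapping one alkyl group for another on the ring, so no firm direction follows from it. He therefore expects compound 4 to show a number 7 percentage points lower from compound 2 to compound 4 (within the scatter) in this assay, a change that stays within the scatter. His estimate for compound 4 is 88%, with a range from 50% to 100%.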

Compound 4, a percentage reported as activity, at one concentration (the size of the read-out at that concentration, not a potency): 100%
The estimate for compound 4 lay 12 percentage points below the measured number, within the range that was stated.
By their numbers in this assay, from the lowest: compound 3; then compounds 1, 2 and 4 (each within the scatter of the next).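

In this assay, tert-butyl in place of ethyl on an aromatic carbon, ortho to a large group, gives a number 5 percentage points higher from compound 2 to compound 4 (within the scatter). This is the first change shown to the alkyl group at this position, and the read-out does not move beyond the scatter when four carbons enter for two. Nothing known here gives a cause for this step.

The compounds shown leave open whether an amine or a carboxylic acid at this position would shift the number. They also leave open whether tert-butyl would behave alike where compound 3 carries its ethyl.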